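A Diastereomer of Compound 1 in Liver Microsomes

The source may report more compounds than this note shows. Statements on the series, on what has been measured and on what is new or still open speak of the compounds shown alone.

Compound 1 `C[C@]1(O)C[C@@](c2ccc(OC(F)(F)F)cc2)([C@@H](O)c2ccccn2)C1`: 50 mL/min/kg
Compound 2 `OC(c1ccc(F)cn1)C1(c2ccc(Cl)c(Cl)c2)CCC1`: 767 mL/min/kg
Compound 3 `OC(c1cc(F)ccn1)C1(c2ccc(Cl)c(Cl)c2)CCC1`: 533 mL/min/kg

In an ADME assay on liver for metabolic stability, with Liver microsome (Homo sapiens) as the target, read by LC-MS, using microsomes, with a stated time of 5 h (a higher number here means faster removal of the compound, a lower number slower removal), compound 1 gives 50 mL/min/kg, the lowest of the three numbers; compound 3 stands nearest with 533 mL/min/kg and compound 2 furthest with 767 mL/min/kg. Among the measured compounds shown here, the only measured step, a 1.4-fold lower number from compound 2 to compound 3 (0.16 log units; within the scatter), concerns a change of substituent on the pyridine and says nothing about configuration. Compound 4 `C[C@]1(O)C[C@](c2ccc(OC(F)(F)F)cc2)([C@H](O)c2ccccn2)C1` differs from compound 1 as follows: the two compounds have the same atoms and bonds and differ only in configuration as drawn: 2 of 3 stereo elements differ; a stereocentre at a saturated ring carbon is drawn s in compound 1 and r in compound 4; a stereocentre at a saturated chain carbon is drawn R in compound 1 and S in compound 4. For the measured compounds named here, no measured pair here differs in configuration alone, so there is no step on which to base a direction. Compound 4 is therefore expected to give a number close to that of compound 1, a 1.2-fold higher number from compound 1 to compound 4 (0.08 log units; within the scatter), with a wide range; nothing measured here speaks to a change of configuration. The estimate for compound 4 is 60 mL/min/kg, between 22 mL/min/kg and 160 mL/min/kg.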

Compound 4, clearance: 50 mL/min/kg
Estimate against measurement, compound 4: 1.2-fold (0.08 log units) above, within the range that was stated.
By their numbers in this assay, from the lowest: compounds 1 and 4 (each within the scatter of the next); then compounds 3 and 2 (each within the scatter of the next).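

In this assay, among the compounds shown here, the change of configuration gives no change at the digits printed from compound 1 to compound 4 (within the scatter), the first comparison here that isolates configuration. Changing the stereocentres at the saturated ring carbon and the saturated chain carbon together therefore leaves the clearance of this pair unmoved, which the step on the pyridine substituent could not show. The comparison is clean on one count: the fact that compounds 1 and 4 differ only in the configuration as drawn

The compounds shown leave open what either stereocentre does alone, as the two change together here. They also leave open whether the same holds for the core of compound 1 when it carries an amine or a carboxylic acid.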